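Dropping the propylsulfonylamino group from an indane imidazole

The compounds below may be only part of what the source reports. "The series", "measured", "known", "first", "only" and "open" are said of these compounds alone.

Measured so far:
- compound 1 `CCCS(=O)(=O)Nc1cccc2c1CCC2c1ncc[nH]1` — > 10000 nM
- compound 2 `CCS(=O)(=O)Nc1cccc(Cc2c[nH]cn2)c1` — > 10000 nM
- compound 3 `CS(=O)(=O)Nc1c(Cl)ccc2c1CCCC2c1ncc[nH]1` — > 10000 nM

Three compounds have been run in a functional assay on CHO cells for agonist activity at Alpha-1B adrenergic receptor (Homo sapiens), read by FLIPR and calcium flux; a lower number here means that less compound is needed, a higher number that more compound is needed for the effect. Compound 1 returns no number, only a limit of > 10000 nM. Compound 2 likewise returns only a limit, > 10000 nM. Compound 3 also gives only a limit, > 10000 nM. Going by the values given here, compound 1 therefore stands nowhere distinct among the values shown: the limit of > 10000 nM in this assay, at which 3 of the 3 values shown sit, and no step between measured compounds can be drawn.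

Compound 4 `c1ccc2c(c1)CCC2c1ncc[nH]1` is not yet measured. It differs from compound 1 in a single place: hydrogen in place of (propylsulfonyl)amino on an aromatic carbon. Since all three values sit at the limit (the limit of > 10000 nM in this assay, at which 3 of the 3 values shown sit), the data give no direction for such a change, and nothing measured speaks for or against the sulfonamide being needed. The step from compound 1 to compound 4 is expected to be an at least 1.6-fold lower number from compound 1 to compound 4 (0.22 log units; that floor lies within the scatter), judged from a starting point that is itself only a limit. Compound 4 is estimated at 6000 nM, with a range from 800 nM to 30000 nM, and a real chance that this assay again reports only a limit.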

Compound 4, half-maximal effective concentration: > 10000 nM
Compound 4: only a limit was reported; the forecaster's own chance of this, stated with the estimate: 60%; at least 1.6-fold (0.22 log units) between middle value and limit.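

Compound 4 gives > 10000 nM, which is a limit and not a number. No step can be read from compound 1 to compound 4, as each reports only a limit: the limit of > 10000 nM in this assay, at which 4 of the 4 values shown sit. The compounds shown leave open whether the (propylsulfonyl)amino group matters at all for agonist activity, and what any of the four would give as an actual number.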